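Swapping a Hydroxyphenyl for a Dichlorophenyl

The source may hold more compounds than are shown below. What is called first, only, known or untested is meant among the compounds shown, and "the series" means these compounds.

Compound 1 `COc1ccc(/C=C2\CCC/C(=C\c3ccccc3Cl)C2=O)cc1OC` gives 21600 nM
Compound 2 `COc1ccccc1/C=C1\CCC/C(=C\c2ccc(OC)c(OC)c2)C1=O` gives 18100 nM
Compound 3 `COc1ccc(/C=C2\CCC/C(=C\c3cccc(O)c3)C2=O)cc1OC` gives 6800 nM

These values come from an ADME assay on NHDF cells (Homo sapiens) for cytotoxicity, read by MTT assay, with a stated time of 72 h (a lower number here means a stronger inhibitor, a higher number a weaker inhibitor), and compound 3 has the lowest of the three. Compound 4 `COc1ccc(/C=C2\CCC/C(=C\c3ccc(Cl)cc3Cl)C2=O)cc1OC` is still unmeasured. It has 2,4-dichlorophenyl in place of 3-hydroxyphenyl on a double-bonded chain carbon bound to a double-bonded ring carbon. Two measured steps change that same place: a 3.2-fold lower number from compound 1 to compound 3 (0.50 log units; beyond the scatter) when 3-hydroxyphenyl replaces 2-chlorophenyl, and a 2.7-fold lower number from compound 2 to compound 3 (0.43 log units; beyond the scatter) when it replaces 2-methoxyphenyl. Both are modest. The swap of chloro for methoxy (a 1.2-fold lower number from compound 1 to compound 2 (0.08 log units; within the scatter)) stays within the scatter. Compound 4 loses 3-hydroxyphenyl, so the two modest steps are expected to run in reverse, towards the higher numbers of the compounds without it. Among the compounds with values here, no measured compound carries 2,4-dichlorophenyl, so the range stays wide. The expected step is a 2.8-fold higher number from compound 3 to compound 4 (0.45 log units; beyond the scatter) in that upward direction. The estimate for compound 4 is 19000 nM within an expected range of 9000 nM to 40000 nM in this test.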

Compound 4, half-maximal inhibitory concentration: > 50000 nM
Compound 4 gave a limit, no number; the forecaster's own chance of this, stated with the estimate: 5%; at least 2.6-fold (0.42 log units) between middle value and limit.
By their numbers in this assay, from the lowest: compound 3; then compounds 2 and 1 (each within the scatter of the next). At a limit, above all of these: compound 4.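

In this assay, compound 4 gives only a limit, not a number: the limit of > 50000 nM in this assay, at which 1 of the 4 values shown sits.

Earlier changes at this position spanned a modest range, but the new result extends it upward, with an at least 7.3-fold higher number from compound 3 to compound 4 (0.86 log units; beyond the scatter) and an at least 2.7-fold higher number from compound 2 to compound 4 (0.44 log units; beyond the scatter). A single added chloro also matters here, giving an at least 2.3-fold higher number from compound 1 to compound 4 (0.36 log units; beyond the scatter), whereas the earlier swap of chloro for methoxy, a 1.2-fold lower number from compound 1 to compound 2 (0.08 log units; within the scatter), stayed within the scatter.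

From the compounds shown here alone, with a limit in place of a number, these steps show only a minimum size, so the full effect of 2,4-dichlorophenyl remains unknown. Compound 3 is the only hydroxyphenyl compound shown, which leaves open whether an aminophenyl or a phenyl ring carrying a carboxylic acid would give a number as low as the one for 3-hydroxyphenyl.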